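Swapping an Aryl for a Benzyl on the Piperazine Nitrogen

The source may report more compounds than this note shows. Statements on the series, on what has been measured and on what is new or still open speak of the compounds shown alone.

Among the measured compounds shown here, compound 2 `O=C1NC(c2ccccc2)(c2ccccc2)C(=O)N1CN1CCN(c2cccc(C(F)(F)F)c2)CC1` gives 100 mg/kg in a functional assay on the whole organism (strain CD1) with Mus musculus as the target, in the maximal electroshock model, with a stated time of 4 h (on this read-out higher numbers stand for an effect only at larger amounts of compound and lower numbers for an effect already at smaller amounts), the higher of the two numbers known, with compound 1 `CN1CCN(CN2C(=O)NC(c3ccccc3)(c3ccccc3)C2=O)CC1` at 10 mg/kg. Compound 3 `O=C1NC(c2ccccc2)(c2ccccc2)C(=O)N1CN1CCN(Cc2ccccc2)CC1` differs from compound 2 by benzyl in place of 3-(trifluoromethyl)phenyl on an amine nitrogen in a ring. For the measured compounds named here, the only step that bears on this site is a 10-fold higher number from compound 1 to compound 2 (1.00 log units; beyond the scatter), which shows that the group on this nitrogen moves the number markedly. A benzyl group is expected to fall between those two cases, so a moderate lowering, a 3.3-fold lower number from compound 2 to compound 3 (0.52 log units; beyond the scatter), is estimated. Compound 3 is therefore expected to give 30 mg/kg, with a range of 10 mg/kg to 100 mg/kg.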

Compound 3, minimum effective dose: 100 mg/kg
Beside the measured number, compound 3's estimate is 3.3-fold (0.52 log units) below it; measured number inside the range.
By their numbers in this assay, from the lowest: compound 1; then compounds 2 and 3 (each within the scatter of the next).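

In this assay the change gives no change at the digits printed from compound 2 to compound 3 (within the scatter) and so shows that, on this amine nitrogen in a ring, benzyl and 3-(trifluoromethyl)phenyl cannot be told apart. Adding phenyl to the methyl group gives a 10-fold higher number from compound 1 to compound 3 (1.00 log units; beyond the scatter) and places compound 3 with compound 2, apart from compound 1. No evidence is available that accounts for this result.

On these data alone, it remains open whether ethyl or hydrogen on this nitrogen would read like compound 1 or like compound 2 and compound 3. As far as these compounds go, the effect of a carboxylic acid on the benzyl ring also remains open.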